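A Shorter Chain on the Core of Compound 1

The source may report more compounds than this note shows. Statements on the series, on what has been measured and on what is new or still open speak of the compounds shown alone.

The study examines compound 1 `Nc1nc(O)c2c(n1)n(C1OC(CO)[C@@H](O)[C@H]1O)c(=O)n2CC(O)CSc1ccccc1` and compound 2 `C=CCn1c(=S)n([C@@H]2O[C@H](CO)[C@H]3OC(C)(C)O[C@H]32)c2nc(N)nc(O)c21` in a functional assay (B cells) with Mus musculus as the target; on this read-out lower numbers stand for an effect already at smaller amounts and higher numbers for an effect only at larger amounts of compound. Compound 1 gives 142 uM, the higher of the two numbers, while compound 2 gives 55 uM, a gap that lies beyond the usual scatter. Compound 3 `CCCCn1c(=O)n(C2OC(CO)[C@@H](O)[C@H]2O)c2nc(N)nc(O)c21` has not been measured; it differs from compound 1 by propyl in place of 1-hydroxy-2-(phenylsulfanyl)ethyl on a saturated chain carbon bound to an aromatic nitrogen. Within the data shown here, with no comparable pair measured, the step from compound 1 to compound 3 is expected to fall within the scatter, with only a slight lowering, if any, as a 1.4-fold lower number from compound 1 to compound 3 (0.15 log units; within the scatter). For compound 3 the expected value is therefore 100 uM, estimated to lie between 30 uM and 300 uM.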

Compound 3, concentration for half-maximal effect: 11 uM
Compound 3: middle estimate off by 9.1-fold (0.96 log units), on the high side; measured number below the stated range.
By their numbers in this assay, from the lowest: compound 3; then compound 2; then compound 1.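

In this assay propyl in place of 1-hydroxy-2-(phenylsulfanyl)ethyl on a saturated chain carbon bound to an aromatic nitrogen gives a 13-fold lower number from compound 1 to compound 3 (1.11 log units; beyond the scatter) and shows that the number at this position responds strongly to the chain. The lower number comes with the aromatic ring, the sulfur and the hydroxy group all gone. No measurement shown gives a reason for this step. Going by these compounds, with all three parts leaving together, the part that carries the step stays open. On these data alone, how a longer chain or a terminal amine would read at this position also remains open.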